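The source may report more compounds than this note shows. Statements on the series, on what has been measured and on what is new or still open speak of the compounds shown alone.

Compound 1: `COc1cccc(-c2cc3c(c(N)nn3C)c(=O)[nH]2)c1`, -5% in an assay on isolated protein for inhibition of RAC-alpha serine/threonine-protein kinase (Homo sapiens), read by mobility shift assay, tested at 30 uM; a lower number here means less inhibition, a higher number more inhibition at the concentration tested (going by the name of the read-out)
Compound 2: `Cc1cc2c(c(N)nn2C)c(N2CC[C@H](O)C2)n1`, 7% in this assay

Of the two compounds measured, compound 2 stands highest in this assay; its nearest neighbour is compound 1, whose number lies lower by a gap beyond the usual scatter. Both numbers, however, sit close to zero, so neither compound shows much inhibition at the concentration tested.

Compound 3 is `Cc1cc2c(cn1)c(N)nn2C`. It differs from compound 2 in one place: hydrogen in place of 3-hydroxypyrrolidin-1-yl on an aromatic carbon. The 3-hydroxypyrrolidin-1-yl group leaves, and a hydrogen enters on the aromatic carbon described.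

No measured step of this kind exists among the compounds shown, so the expectation rests on the weak numbers of compound 1 and compound 2 alone. The step is estimated to be small and downward, about a number 5 percentage points lower from compound 2 to compound 3 (within the scatter), within the scatter. Compound 3 is therefore expected to give 2% in this assay, within a range from -10% to 14%.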

Compound 3, a percentage reported as inhibition, at one concentration (the size of the read-out at that concentration, not a potency): 0%
Compound 3: middle estimate off by 2 percentage points, on the high side, and the stated range covers the measured number.
By their numbers in this assay, from the lowest: compounds 1, 3 and 2 (each within the scatter of the next, the first and the last beyond it).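

Among these compounds, exchanging the 3-hydroxypyrrolidin-1-yl group for hydrogen on this aromatic carbon, next to the ring nitrogen, gives a number 7 percentage points lower from compound 2 to compound 3 (within the scatter) in this assay and provides the first comparison between compounds that differ in one place. The whole group can therefore leave this position without a change that stands out from the scatter, so the small number for compound 2 cannot be tied to that group. No supporting measurement bears on this result.

As far as these compounds go, it remains open whether another group on the same carbon, such as a primary amine, a carboxylic acid or a longer alkyl chain, would raise inhibition clearly above these low numbers. From the compounds shown here alone, the effect of a morpholine or piperazine ring at this position also remains open.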